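A few compounds are considered here, and "the series" means these few. Any claim that something is new, unique, unknown or untested is made for them only; others in the source may bear on it.

Working notes on the series. Of the compounds shown here, three sharing one core have been measured in a functional assay on IMR-32 cells for inhibition of Voltage-dependent N-type calcium channel subunit alpha-1B (Homo sapiens), read by calcium flux; on this read-out lower numbers stand for stronger inhibition and higher numbers for weaker inhibition. Compound 1 `CC1=NC(C)=C(C(=O)O)C(c2ccccc2[N+](=O)[O-])/C1=C(\O)OC/C=C/c1ccccc1` gives 37000 nM. Compound 2 `CC1=NC(C)=C(C(=O)O)C(c2cccc(C(=O)O)c2)/C1=C(\O)OC/C=C/c1ccccc1` gives 37000 nM. Compound 3 `CC1=NC(C)=C(C(=O)O)C(c2cccnc2)/C1=C(\O)OC/C=C/c1ccccc1` gives 24000 nM, the lowest number of the three, though its steps to the other two lie within the scatter, so no order among them is claimed. All three measured steps exchange the group on the saturated ring carbon: no change at the digits printed from compound 1 to compound 2 (within the scatter), a 1.5-fold lower number from compound 1 to compound 3 (0.19 log units; within the scatter) and a 1.5-fold lower number from compound 2 to compound 3 (0.19 log units; within the scatter); none moves the read-out beyond the scatter.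

Compound 4 `CC1=NC(C)=C(C(=O)O)C(c2ccsc2)/C1=C(\O)OC/C=C/c1ccccc1` is a further exchange at that same carbon: thiophen-3-yl in place of pyridin-3-yl on a saturated ring carbon. The three steps at this position bear on it directly, and each stayed within the scatter, so the expected step in this assay is a 1.2-fold higher number from compound 3 to compound 4 (0.07 log units; within the scatter), meaning no change beyond the scatter in either direction. Compound 4 is therefore estimated at 28000 nM, with a range from 12000 nM to 70000 nM. Among the measured compounds shown here, three compounds are a thin base, and the thiophen-3-yl ring is the only five-membered group at this carbon, so nothing measured speaks to it specifically.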

Compound 4, half-maximal inhibitory concentration: 2900 nM
For compound 4 the middle estimate is 9.7-fold (0.98 log units) above the measured one; measured number outside the range, below it.
By their numbers in this assay, from the lowest: compound 4; then compounds 3, 1 and 2 (each within the scatter of the next).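

In this assay, among the compounds shown here, the saturated ring carbon now shows a step beyond the scatter for the first time: thiophen-3-yl gives a clear change in place of pyridin-3-yl (an 8.3-fold lower number from compound 3 to compound 4 (0.92 log units; beyond the scatter)), and larger ones in place of 3-carboxyphenyl (a 13-fold lower number from compound 2 to compound 4 (1.11 log units; beyond the scatter)) and 2-nitrophenyl (a 13-fold lower number from compound 1 to compound 4 (1.11 log units; beyond the scatter)). The group at this carbon therefore does affect the read-out, with the one five-membered aromatic ring standing apart from the three six-membered groups, which remain within the scatter of one another. Nothing available explains this gap.

A furan-3-yl, thiophen-2-yl or unsubstituted phenyl group at this carbon would separate the role of ring size from that of the sulfur atom. On these data alone, whether the step holds with a methyl ester in place of the carboxy group on the shared core also remains open.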